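Swapping a branched alkyl for a dialkylamino on a diazine core

The source may report more compounds than this note shows. Statements on the series, on what has been measured and on what is new or still open speak of the compounds shown alone.

Measured compounds:
compound 1, `CCc1nc(-c2ccc(OC(F)(F)F)cc2OC)c(OC)nc1NC(CC)CC`, 6.1 nM
compound 2, `CCc1nc(-c2ccc(Cl)cc2Cl)c(CC)nc1CC(CC)CC`, 68 nM

Both compounds were tested in an assay on IMR-32 cells for displacement of a labelled ligand from corticotropin-releasing factor receptor 1 (Homo sapiens), read by scintillation counting, with a stated time of 2 h; on this read-out lower numbers stand for stronger inhibition and higher numbers for weaker inhibition. In this assay compound 1 gives 6.1 nM, and compound 2 gives 68 nM. Compound 2 therefore stands at the higher of the two numbers, and the gap to compound 1 is beyond the scatter; the two compounds differ in several places at once, so no single change can be credited for it.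

Compound 3, `CCCN(CC1CC1)c1nc(CC)c(-c2ccc(Cl)cc2Cl)nc1CC`, has not yet been measured in this assay. It keeps the core and the 2,4-dichlorophenyl group of compound 2 and differs in one place: (cyclopropylmethyl)(propyl)amino in place of 2-ethylbutyl on an aromatic carbon. The entering group brings a nitrogen attached to the ring where compound 2 has only a carbon chain; compound 1, which carries a nitrogen at the same kind of position, has the lower number 6.1 nM, although it also differs elsewhere, so that comparison is only suggestive.

For compound 3 the expected outcome is a lower number than for compound 2, a step of a 4.5-fold lower number from compound 2 to compound 3 (0.66 log units; beyond the scatter), somewhat beyond the scatter. The estimate for compound 3 in this assay is 15 nM, with a range from 4 nM to 60 nM.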

Compound 3, inhibition constant: 19.2 nM
Estimate against measurement, compound 3: 1.3-fold (0.11 log units) below, and the stated range covers the measured number.
By their numbers in this assay, from the lowest: compound 1; then compound 3; then compound 2.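

Placing (cyclopropylmethyl)(propyl)amino where 2-ethylbutyl stood gives a 3.5-fold lower number from compound 2 to compound 3 (0.55 log units; beyond the scatter) in this assay. The step is modest but beyond the usual scatter, and unlike the gap between compound 1 and compound 2, it comes from a change in one place, with the core and the 2,4-dichlorophenyl group held constant, so it can be credited to this swap on the ring carbon next to the ring nitrogen. Even so, the swap alters several things at once, including the atom attached to the ring, the size of the group and the presence of a three-membered ring, and no measurement here identifies which of these matters.

The compounds shown leave open whether the nitrogen alone accounts for the step, a question that a simple dipropylamino group at this position, with no three-membered ring, would help to address. They also leave open whether the same swap gives a similar step with another aryl group, such as the 2-methoxy-4-(trifluoromethoxy)phenyl group of compound 1, in place of 2,4-dichlorophenyl.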